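The compounds below may be only part of what the source reports. "The series", "measured", "known", "first", "only" and "open" are said of these compounds alone.

Of the compounds shown here, two have been measured in an assay on cell membranes for displacement of a labelled ligand from corticotropin-releasing factor receptor 1 (Rattus norvegicus); on this read-out higher numbers stand for weaker inhibition and lower numbers for stronger inhibition. Compound 1 `CCC1CCCCN1c1nc(C)nc2c(-c3c(C)cc(OC)cc3OC)c(C)nn12` gives 3.26 nM, and compound 2 `CCCCN(CC)c1nc(C)nc2c(-c3c(C)cc(OC)cc3OC)c(C)nn12` gives 1.72 nM. Within the data shown here, the one measured step is a 1.9-fold lower number from compound 1 to compound 2 (0.28 log units; within the scatter). On these two numbers compound 2 stands lowest, though its gap to compound 1 is within the scatter, so no order between them can be claimed.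

Compound 3 `C=CCN(CC=C)c1nc(C)nc2c(-c3c(C)cc(OC)cc3OC)c(C)nn12` has not yet been measured. It differs from compound 2 in one place: diallylamino in place of butyl(ethyl)amino on an aromatic carbon. Among the measured compounds shown here, the only step that bears on this change is the one from compound 1 to compound 2, where a different group on the same aromatic carbon was exchanged and the number moved by a 1.9-fold lower number from compound 1 to compound 2 (0.28 log units; within the scatter), within the scatter. Since both groups here have the same count of heavy atoms and the shared core is unchanged, the expected step in this assay is small, likely none beyond the scatter, with a 1.5-fold higher number from compound 2 to compound 3 (0.16 log units; within the scatter) as the expected shift. Compound 3 is estimated at 2.5 nM, expected to fall between 0.9 nM and 7 nM.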

Compound 3, half-maximal inhibitory concentration: 1 nM
Compound 3: middle estimate off by 2.5-fold (0.40 log units), on the high side, and the stated range covers the measured number.
By their numbers in this assay, from the lowest: compounds 3, 2 and 1 (each within the scatter of the next, the first and the last beyond it).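

On the aromatic carbon between two ring nitrogen atoms, diallylamino, with its 2 double bonds outside aromatic rings, can take the place of butyl(ethyl)amino with no readable difference in this assay (a 1.7-fold lower number from compound 2 to compound 3 (0.24 log units; within the scatter)). Diallylamino in place of the ring-containing 2-ethylpiperidin-1-yl gives the first step at this position to pass the scatter, though only a modest one (a 3.3-fold lower number from compound 1 to compound 3 (0.51 log units; beyond the scatter)). No measurement here explains either step.

The shared core and the other substituents stay the same throughout, so these compounds show only how three amino groups compare at this one position. As far as these compounds go, it remains open how a dipropylamino group, which has chains without double bonds, or a bis(2-methoxyethyl)amino group, which has an ether oxygen in each chain, would compare.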